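The compounds below may be only part of what the source reports. "The series", "measured", "known", "first", "only" and "open" are said of these compounds alone.

In a functional assay on HepG2 cells (Homo sapiens) for antiproliferative activity, read by MTT assay, with a stated time of 24 h (a higher number here means a weaker inhibitor, a lower number a stronger inhibitor), compound 2 `C=CCOc1ccc(-c2ccc(OC)cc2)cc1CC=C` gives no number, only a limit of the assay (> 100000 nM). Compound 1 `C=CCc1cc(C=O)c(OCC(=O)OCC)c(-c2ccc(OCC(=O)OCC)c(CC=C)c2)c1` also gives only a limit (> 85200 nM). Compound 3 `C=CCc1cc(-c2ccccc2C(F)(F)F)ccc1O` is the only one of the three with a true value (52400 nM), and it is also the only one that carries a hydroxy on an aromatic ring. Three compounds are too few to make this a rule.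

Compound 4 `C=CCc1cc(-c2ccc(OC)cc2)ccc1O` departs from compound 2 by one change hydrogen in place of allyl on an oxygen on an aromatic ring in which hydrogen takes the place of allyl on an oxygen on an aromatic ring, turning allyloxy to hydroxy. Among the measured compounds shown here, no measured pair shows this change, so the expectation leans on compound 3 and its 52400 nM as the sole guide for a compound with a free hydroxy. In this assay the change is expected to give a stronger inhibitor, but only modestly so, and a second limit remains a real possibility. The estimated move is an at least 2.0-fold lower number from compound 2 to compound 4 (0.30 log units; that floor lies within the scatter) and it is counted from a limit rather than from a number, so its true size may be larger. Compound 4 is estimated at 50000 nM (expected range 20000 nM to 100000 nM).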

Compound 4, half-maximal inhibitory concentration: > 100000 nM
Compound 4 ended at the assay's limit; the forecaster's own chance of this, stated with the estimate: 35%; middle value at least 2.0-fold (0.30 log units) away from the limit.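

Compound 2 and compound 4 both end at a limit of this assay rather than at a number, so no step between them can be read: the limit of > 100000 nM in this assay, at which 2 of the 4 values shown sit.

The compounds shown leave open whether hydrogen in place of allyl on an oxygen on an aromatic ring changes the reading in this assay at all.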